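The source may report more compounds than this note shows. Statements on the series, on what has been measured and on what is new or still open speak of the compounds shown alone.

Compound 1 `Cc1ccc2c(NCc3ccc(NC(=O)C4CCN(Cc5ccc(F)cc5)CC4)cc3)nc(N(C)C)nc2c1` was tested in a functional assay on SV5A8 cells (Homo sapiens) for cytotoxicity (a higher number here means a weaker inhibitor, a lower number a stronger inhibitor), where compound 1 gives > 4820 nM, which is a limit of the assay and not a number. Two related compounds share the same core. Compound 2 `Cc1ccc2c(NCc3ccc(NC(=O)C4CCN(Cc5ccccc5)CC4)cc3)nc(N3CCN[C@@H](C)C3)nc2c1` gives > 8860 nM in this assay, again only a limit. Compound 3 `Cc1ccc2c(NCc3ccc(NC(=O)C4CCN(Cc5ccccc5)CC4)cc3)nc(N(C)CCCN(C)C)nc2c1` gives > 8620 nM in this assay, also a limit. The step that the two limits leave unreadable from compound 2 to compound 3 therefore cannot be read, since both ends are limits. Among the measured compounds shown here, compound 1 thus stands at a limit, at the limit of > 4820 nM in this assay, at which 1 of the 3 values shown sits, and the two other values shown are limits as well, at the limit of > 8620 nM in this assay, at which 1 of the 3 values shown sits, and (the limit of > 8860 nM in this assay, at which 1 of the 3 values shown sits); no compound here can be called stronger or weaker than another.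

Compound 4 `Cc1ccc2c(NCc3ccc(NC(=O)C4CCN(Cc5cc(Cl)ccn5)CC4)cc3)nc(N(C)C)nc2c1` differs from compound 1 in one place: 4-chloropyridin-2-yl in place of 4-fluorophenyl on a saturated chain carbon bound to an amine nitrogen in a ring. For the measured compounds named here, no measured step touches this change; the only step that exists, from compound 2 to compound 3, sits elsewhere on the core and is itself unreadable. Going by the values given here, with every value so far a limit, the expectation for compound 4 is another weak inhibitor, most likely reported again as a limit. The expected outcome for compound 4 is a step that the limit leaves unreadable from compound 1 to compound 4. Compound 4 is estimated at 8000 nM, with a range from 2500 nM to 25000 nM.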

Compound 4, half-maximal inhibitory concentration: > 5400 nM
Compound 4: no number, only a limit; the forecaster's own chance of this, stated with the estimate: 75%; the middle value lies beyond the limit too.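

Compound 4 gives > 5400 nM in this assay, which is a limit and not a number. Compound 1 gives > 4820 nM, also a limit, so the step between compound 1 and compound 4 cannot be read. The compounds shown leave open what any of them actually measures in this assay, and whether 4-chloropyridin-2-yl in place of 4-fluorophenyl changes it at all.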